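From a Hydroxyl Tail to a Carboxylic Acid Tail

The source may hold more compounds than are shown below. What is called first, only, known or untested is meant among the compounds shown, and "the series" means these compounds.

Three measured compounds share one core and differ only in the chain attached to the sulfur. Compound 1 `CC(C)CCSc1nc(C(F)(F)F)ccc1CNC(=O)C(C)c1ccc(NS(C)(=O)=O)c(F)c1` carries a chain ending in isopropyl and, in an assay on CHO-K1 cells for antagonist activity at transient receptor potential cation channel subfamily V member 1 (Homo sapiens), read by FLIPR (on this read-out lower numbers stand for stronger inhibition and higher numbers for weaker inhibition), compound 1 gives 0.7 nM. Compound 2 `CC(C(=O)NCc1ccc(C(F)(F)F)nc1SCCOc1ccccc1)c1ccc(NS(C)(=O)=O)c(F)c1` carries a chain ending in phenoxy; in this assay compound 2 gives 2.3 nM. Among the measured compounds shown here, the one measured step, a 3.3-fold higher number from compound 1 to compound 2 (0.52 log units; beyond the scatter), shows that exchanging the end of the chain can weaken binding, though only modestly. Compound 3 `CC(C(=O)NCc1ccc(C(F)(F)F)nc1SCCCO)c1ccc(NS(C)(=O)=O)c(F)c1` carries a chain ending in a hydroxyl group, and in this assay compound 3 is reported as "not active" (no number reported), so no number stands for it: on the numbers shown it sits apart from compounds 1 and 2, both of which bind tightly.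

Compound 4 `CC(C(=O)NCc1ccc(C(F)(F)F)nc1SCCC(=O)O)c1ccc(NS(C)(=O)=O)c(F)c1` differs from compound 3 in one place: carboxy in place of hydroxymethyl on a saturated chain carbon, two bonds along the chain from a sulfur. For the measured compounds named here, no measured step bears directly on this exchange; the step from compound 1 to compound 2 concerns a different chain end and was modest in size. Going by the values given here, with compound 3 giving no number at all, nothing among the measured compounds suggests that the carboxy group would restore tight binding. Compound 4 is therefore expected to bind weakly or not at all, with an estimated value of 5000 nM, in a range from 800 nM to 30000 nM.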

Compound 4, inhibition constant: "not active" (no number reported)
For compound 4 the study gives words and no number, and the estimate cannot be compared.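

Compound 3 and compound 4 are both reported in this assay as not active, without a number, so no step can be read between them. Nothing measured here accounts for this result. The compounds shown leave open how far the hydroxyl and carboxy chain ends each fall short of compound 1 and compound 2.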